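A few compounds are considered here, and "the series" means these few. Any claim that something is new, unique, unknown or untested is made for them only; others in the source may bear on it.

Three compounds have been measured in an in vitro assay on HEK385-7 cells for displacement of a labelled ligand from prostaglandin D2 receptor 2 (Homo sapiens); on this read-out lower numbers stand for stronger inhibition and higher numbers for weaker inhibition:
compound 1 `O=C(O)Cc1sc(CS(=O)(=O)c2ccc(Cl)cc2)nc1-c1ccc(Cl)cc1`, 1500 nM;
compound 2 `O=C(O)Cc1sc(Cc2ccccc2-c2ccccc2)nc1-c1ccc(Cl)cc1`, 41 nM;
compound 3 `O=C(O)Cc1sc(C(c2ccc(F)cc2)c2ccc(F)cc2)nc1-c1ccccc1`, 16 nM.

Among these, compound 3 gives the lowest number. Its nearest neighbour is compound 2, whose value lies beyond the usual scatter above it, while compound 1 sits far higher still. Compound 4 `Cc1cc(-c2nc(C(c3ccc(F)cc3)c3ccc(F)cc3)sc2CC(=O)O)ccn1` has not been measured. It differs from compound 3 in one place: 2-methylpyridin-4-yl in place of phenyl on an aromatic carbon. For the measured compounds named here, no step between measured compounds mirrors this exchange, so the record offers no direct guide to its size. A small step is expected, if any, tending toward a somewhat higher number but close to the scatter. Compound 4 is expected to give 25 nM in this assay, with a range from 8 nM to 80 nM. The step this estimate implies is a 1.6-fold higher number from compound 3 to compound 4 (0.19 log units; within the scatter).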

Compound 4, half-maximal inhibitory concentration: 3.1 nM
For compound 4 the middle estimate is 8.1-fold (0.91 log units) above the measured one, and the stated range ends above it.
By their numbers in this assay, from the lowest: compound 4; then compound 3; then compound 2; then compound 1.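

In this assay, for the compounds shown here, the exchange of phenyl for 2-methylpyridin-4-yl on the aromatic carbon next to the ring nitrogen gives a 5.2-fold lower number from compound 3 to compound 4 (0.71 log units; beyond the scatter) and is the only single-place step. It shows that this position takes a six-membered aromatic ring with a hetero atom and a methyl group, and that the number falls rather than rises. No measurement here gives a reason for this step.

From the compounds shown here alone, whether the ring nitrogen or the methyl group carries the step stays open. A plain pyridin-4-yl at this position would separate the two.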